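A few compounds are considered here, and "the series" means these few. Any claim that something is new, unique, unknown or untested is made for them only; others in the source may bear on it.

Values in a functional assay on DU-145 cells (Homo sapiens) for cytotoxicity, read by trypan blue exclusion, with a stated time of 96 h; a higher number here means a weaker inhibitor, a lower number a stronger inhibitor:
compound 1 `COc1cc(OC)c(/C=C/S(=O)(=O)Cc2ccc(OC)c(N)c2)c(OC)c1`: 4 nM
compound 2 `COc1cc(OC)c(/C=C/S(=O)(=O)Cc2ccc(Cl)c(N)c2)c(OC)c1`: 10 nM
compound 3 `COc1cc(OC)c(/C=C/[S+]([O-])Cc2ccc(OC)c([N+](=O)[O-])c2)c(OC)c1`: 15000 nM
compound 4 `COc1cc(OC)c(/C=C/[S+]([O-])Cc2ccc(OC)c(N)c2)c(OC)c1`: not yet measured

Compound 3, at 15000 nM, has the highest number of the three, far above compound 2 and further still above compound 1. The next change is amino in place of nitro on an aromatic carbon, which gives compound 4.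

Among the compounds with values here, the only measured step, a 2.5-fold higher number from compound 1 to compound 2 (0.40 log units; beyond the scatter), is modest. It is a chloro in place of methoxy change, so it says little about a nitro to amino change. Within the data shown here, no measured pair isolates that change. Compounds 1 and 2 carry the amino group, but they have a sulfonyl linker where compound 3 and compound 4 have a sulfinyl one, so the gap to compound 3 cannot be assigned to the nitro group alone.

The expectation of a large fall in this assay rests on compound 1 at 4 nM and compound 2 at 10 nM, both of which carry the amino group. Only part of that gap is expected to be recovered, and the uncertainty is wide. The estimated change is a 100-fold lower number from compound 3 to compound 4 (2.00 log units; beyond the scatter), towards a lower number and well beyond the scatter. For compound 4 the estimate is 150 nM, with an expected range of 10 nM to 3000 nM.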

Compound 4, half-maximal inhibitory concentration: 40 nM
Estimate against measurement, compound 4: 3.8-fold (0.57 log units) above; low and high end bracket the measured number.
By their numbers in this assay, from the lowest: compound 1; then compound 2; then compound 4; then compound 3.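

Amino in place of nitro, on the aromatic carbon ortho to a methoxy group, gives a 380-fold lower number from compound 3 to compound 4 (2.57 log units; beyond the scatter) in this assay. Within the data shown here, this is the first step that isolates this position with the sulfinyl linker held constant, and it is far larger than the only earlier step, so the group here carries much more weight in this assay than the chloro in place of methoxy change suggested. With the amino group in place, compound 4 reaches 40 nM, and its sulfonyl counterpart compound 1 stands at 4 nM, so a sulfinyl linker is compatible with a low nanomolar-range number once the nitro group has gone. Nothing available explains why the step is this large.

The compounds shown leave open whether other groups at this position, such as a hydroxyl, an acetamide or a dimethylamino group, would hold the number of compound 4. They also leave open how the nitro group behaves with a sulfonyl linker, and whether chloro in place of methoxy has a similar effect with a sulfinyl linker.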